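Urea for phenyl on the pyrrolidine of compound 3

A few compounds are considered here, and "the series" means these few. Any claim that something is new, unique, unknown or untested is made for them only; others in the source may bear on it.

Compound 1 `O=C(CCc1ccc(C(F)(F)F)cc1)Nc1ccc2nc(N3CC4CC3CN4)ccc2c1`, 210 nM; compound 2 `CN(c1ccc2cc(NC(=O)CCc3ccc(C(F)(F)F)cc3)ccc2n1)C1CCCCC1`, 18 nM; compound 3 `O=C(CCc1ccc(C(F)(F)F)cc1)Nc1ccc2nc(N3CCC(c4ccccc4)C3)ccc2c1`, 25 nM.

In an assay on isolated protein for displacement of a labelled ligand from melanin-concentrating hormone receptor 1 (Homo sapiens) (a lower number here means a stronger inhibitor, a higher number a weaker inhibitor), compound 3 stands second of the three, with compound 2 nearest (a 1.4-fold higher number from compound 2 to compound 3 (0.14 log units; within the scatter)) and compound 1 furthest (an 8.4-fold lower number from compound 1 to compound 3 (0.92 log units; beyond the scatter)). Compound 4 `CNC(=O)NC1CCN(c2ccc3cc(NC(=O)CCc4ccc(C(F)(F)F)cc4)ccc3n2)C1` is not yet measured; it differs from compound 3 by (methylcarbamoyl)amino in place of phenyl on a saturated ring carbon. Among the compounds with values here, no measured step exchanges a phenyl for this group. The steps of a 12-fold lower number from compound 1 to compound 2 (1.07 log units; beyond the scatter) and an 8.4-fold lower number from compound 1 to compound 3 (0.92 log units; beyond the scatter) show that altering the amine group on the shared core shifts the number well beyond the scatter, while a 1.4-fold higher number from compound 2 to compound 3 (0.14 log units; within the scatter) does not. Compound 4 is therefore expected to give a higher number, estimated at 150 nM (range 40 nM to 600 nM), a step of a 6.0-fold higher number from compound 3 to compound 4 (0.78 log units; beyond the scatter).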

Compound 4, half-maximal inhibitory concentration: 6 nM
Compound 4: the middle estimate sits 25-fold (1.40 log units) above what was measured; the whole stated range lies above it.
By their numbers in this assay, from the lowest: compound 4; then compounds 2 and 3 (each within the scatter of the next); then compound 1.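

In this assay, the pyrrolidine of the shared core does not depend on an aromatic ring at this saturated ring carbon: (methylcarbamoyl)amino, which has no ring, replaces phenyl and gives a lower number (a 4.2-fold lower number from compound 3 to compound 4 (0.62 log units; beyond the scatter)). This group also betters the cyclohexyl(methyl)amino group (a 3.0-fold lower number from compound 2 to compound 4 (0.48 log units; beyond the scatter)) and the bridged amine group of compound 1 (a 35-fold lower number from compound 1 to compound 4 (1.54 log units; beyond the scatter)), so the amine position holds more than compounds 2 and 3 showed. Nothing at hand bears on what lies behind this result.

The compounds shown leave open how a plain amine, an acetamide or an ethyl urea would fare on this ring carbon. They also leave open whether the urea works equally well on a piperidine ring.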